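Swapping chloro for iodo on an aromatic carbon

The compounds below may be only part of what the source reports. "The series", "measured", "known", "first", "only" and "open" are said of these compounds alone.

Three compounds have been measured in a functional assay on U-87MG ATCC cells (Homo sapiens) for cytotoxicity, read by MTT assay, with a stated time of 48 h (a lower number here means a stronger inhibitor, a higher number a weaker inhibitor), so far:
compound 1 `C/C(=N\NC(=S)Nc1ccccc1I)c1ccccn1` gives 6.1 nM
compound 2 `C/C(=N\NC(=S)Nc1ccc(Cl)cc1)c1ccccn1` gives 1.7 nM
compound 3 `CC(=NNC(=S)Nc1ccccc1F)c1ccccn1` gives 5 nM

Compound 2 has the lowest number of the three (1.7 nM). Compound 3 (5 nM) and compound 1 (6.1 nM) both stand above it by more than the scatter, and those two lie within the scatter of each other.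

The next compound, compound 4 `C/C(=N\NC(=S)Nc1ccc(I)cc1)c1ccccn1`, differs from compound 2 in one group: iodo in place of chloro on an aromatic carbon, para to a large group iodo in place of chloro on an aromatic carbon in the comparison. Among the measured compounds shown here, no measured pair shows this exchange. Compound 1 (6.1 nM) also carries iodo, though not para to a large group, so it offers no direct guide.

In this assay no step beyond the scatter is expected, so compound 2 (1.7 nM) serves as the anchor. The estimated 1.3-fold higher number from compound 2 to compound 4 (0.11 log units; within the scatter) is accordingly small. The estimated value for compound 4 is 2.2 nM with an expected range (0.8 nM to 6 nM).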

Compound 4, half-maximal inhibitory concentration: 59 nM
Beside the measured number, compound 4's estimate is 27-fold (1.43 log units) below it; the measured number lies above the stated range.
By their numbers in this assay, from the lowest: compound 2; then compounds 3 and 1 (each within the scatter of the next); then compound 4.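

In this assay, iodo in place of chloro on an aromatic carbon, para to a large group, gives a 35-fold higher number from compound 2 to compound 4 (1.54 log units; beyond the scatter). No earlier pair had shown any step at this place, and this first one shows that the read-out can change sharply with the group there, even though each group counts as one heavy atom with no hydrogen-bond donors or acceptors. Nothing measured here accounts for the size of the step.

Only chloro and iodo are shown at this place, so it remains open whether fluoro, methyl or methoxy there would give a number closer to that of compound 2 or of compound 4. A single pair also cannot tell whether the same exchange would give a step of this size elsewhere on the ring.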